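One amino group swapped in a low-dose compound

The source may report more compounds than this note shows. Statements on the series, on what has been measured and on what is new or still open speak of the compounds shown alone.

- Compound 1 `CCOC(=O)C(=O)Nc1ccc(N)cc1C#N`: 8.8 mg/kg
- Compound 2 `CCOC(=O)C(=O)Nc1cccc(N)c1C#N`: 0.07 mg/kg
- Compound 3 `CCOC(=O)C(=O)Nc1cc(N(C)C)ccc1C#N`: > 100 mg/kg

These three compounds were tested in a functional assay on the whole organism with Rattus norvegicus as the target (on this read-out higher numbers stand for an effect only at larger amounts of compound and lower numbers for an effect already at smaller amounts), where a small number is the better result. Compound 2 gives 0.07 mg/kg, the lowest of the numbers shown. Its nearest neighbour on the scale is compound 1 at 8.8 mg/kg, and that gap lies well beyond the usual scatter. Compound 3 gives > 100 mg/kg, which is a limit of the assay and not a number.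

The next compound to be tested is compound 4 `CCOC(=O)C(=O)Nc1cccc(N(C)C(C)C)c1C#N`. It keeps the core of compound 2 and changes one group, with isopropyl(methyl)amino in place of amino on an aromatic carbon. Within the data shown here, no measured pair shows this kind of swap, so any forecast is loose. Compound 2 at 0.07 mg/kg sits far below compound 1 at 8.8 mg/kg, so a change on this core could plausibly move the number a long way, and from so low a start the likelier direction is upward. The expected change is a 4.3-fold higher number from compound 2 to compound 4 (0.63 log units; beyond the scatter), a moderate rise that remains an estimate. Compound 4 is estimated at 0.3 mg/kg, with an expected range from 0.03 mg/kg to 5 mg/kg.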

Compound 4, dose for half-maximal effect: 1.2 mg/kg
Estimate against measurement, compound 4: 4.0-fold (0.60 log units) below, within the range that was stated.
By their numbers in this assay, from the lowest: compound 2; then compound 4; then compound 1. At a limit, above all of these: compound 3.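

In this assay, putting isopropyl(methyl)amino in place of amino on this aromatic carbon, ortho to a cyano group, gives a 17-fold higher number from compound 2 to compound 4 (1.23 log units; beyond the scatter), so the result at this position depends strongly on the group placed there. The effect is nevertheless not lost: compound 4 gives 1.2 mg/kg, although the entering group has 0 hydrogen-bond donors and 5 heavy atoms, so neither a donor on this group nor a group of only 1 heavy atom is needed to obtain a measured dose. Compound 3 remains the only compound at a limit of the assay, which is not a number, whereas compound 4 joins those with measured doses: the limit of > 100 mg/kg in this assay, at which 1 of the 4 values shown sits.

This single swap removes the donors and adds carbon atoms at the same time, so the compounds shown cannot separate the contribution of either change to the rise. Methylamino would keep a hydrogen on the nitrogen and add one methyl, while isopropylamino would keep that hydrogen and add the branched chain, and neither group is among the compounds shown.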